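The source may report more compounds than this note shows. Statements on the series, on what has been measured and on what is new or still open speak of the compounds shown alone.

Compound 3 (`CCc1nc(-c2ccc(Cl)cc2Cl)c(CC)nc1NC(C1CC1)C1CC1`) gives 0.183 h in an in vitro ADME assay on microsomes (Homo sapiens) for metabolic stability (a lower number here means that the compound disappears faster, a higher number that the compound lasts longer), and compound 1 (`CCc1nc(-c2ccc(Cl)cc2Cl)c(CC)nc1NC(COC)COC`) gives 0.15 h within the scatter of it. Compound 2 (`CCOc1nc(-c2ccc(Cl)cc2Cl)c(CC)nc1NC(CC)CC`) gives 2 h in this assay and lies beyond the scatter from compound 3, but the two differ in more than one place, so that gap cannot be tied to a single change.

The next structure is compound 4 (`CCc1nc(N(CC2CC2)CC2CC2)c(CC)nc1-c1ccc(Cl)cc1Cl`). The change is bis(cyclopropylmethyl)amino in place of (dicyclopropylmethyl)amino on an aromatic carbon and it gives up the hydrogen-bond donor on that nitrogen. Within the data shown here, the one measured step at this nitrogen is a 1.2-fold higher number from compound 1 to compound 3 (0.09 log units; within the scatter) and it replaces one group with another without leaving the scatter. Among the measured compounds shown here, no measured pair covers the loss of that donor, so the range stays wide.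

The expected result is a 1.1-fold higher number from compound 3 to compound 4 (0.04 log units; within the scatter) in this assay with no step beyond the scatter anticipated. For compound 4 the estimated half-life is 0.2 h with an expected range of 0.08 h to 0.5 h in this series.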

Compound 4, half-life: 0.133 h
Compound 4: middle estimate off by 1.5-fold (0.18 log units), on the high side; the range from low to high includes it.
By their numbers in this assay, from the lowest: compounds 4, 1 and 3 (each within the scatter of the next); then compound 2.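

In this assay, the step to the tertiary amine is small: a 1.4-fold lower number from compound 3 to compound 4 (0.14 log units; within the scatter), so giving up the hydrogen-bond donor on this nitrogen, together with moving the cyclopropyl groups onto separate methylene arms, does not separate the two compounds. The ether-bearing side chain and bis(cyclopropylmethyl)amino also stay together, with a 1.1-fold lower number from compound 1 to compound 4 (0.05 log units; within the scatter), so all three amino groups on this aromatic carbon now sit within the scatter of one another. No measurement at hand accounts for this insensitivity.

Open, going by these compounds, is whether any group at this position moves the half-life beyond the scatter, for instance dipropylamino or bis(2-hydroxyethyl)amino. Also open, on these data alone, is which single change separates the core of compound 2, at 2 h, from the rest of the series.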